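This account rests on a few compounds, and the source may have more. Where it says the series, first, only, none or still open, it means among the compounds named here.

Compound 1 `CCCCNc1nc(N)nc(C)c1CC` and compound 2 `CCCCNc1nc(N)nc(C)c1CCCC(C)(C)O` share one core and differ only in the chain on it. In an assay on HEK293 cells for agonist activity at Toll-like receptor 8 (Homo sapiens), read by spectrophotometry (on this read-out lower numbers stand for an effect already at smaller amounts and higher numbers for an effect only at larger amounts of compound), compound 1 gives 1660 nM, and compound 2 gives 1220 nM. For the measured compounds named here, of the two numbers so far, compound 2 holds the lower one, but the step of a 1.4-fold lower number from compound 1 to compound 2 (0.13 log units; within the scatter) lies within the ordinary scatter, so the two compounds are not told apart. Compound 3 `CCCCNc1nc(N)nc(C)c1CCCC` has not yet been measured. It differs from compound 2 in that (methyl in place of 1-hydroxy-1-methylethyl on a saturated chain carbon, three bonds along the chain from an aromatic carbon). Going by the values given here, the only measured step that touches this part of the molecule is the one from compound 1 to compound 2, and it changed nothing beyond the scatter. The chain of compound 3 stands between those of compound 1 and compound 2 in length, so no step beyond the scatter is expected in this assay; compound 3 is estimated at 1400 nM, within 700 nM to 2800 nM, that is a 1.1-fold higher number from compound 2 to compound 3 (0.06 log units; within the scatter).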

Compound 3, half-maximal effective concentration: 780 nM
Beside the measured number, compound 3's estimate is 1.8-fold (0.25 log units) above it, and the stated range covers the measured number.
By their numbers in this assay, from the lowest: compounds 3, 2 and 1 (each within the scatter of the next, the first and the last beyond it).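

Ethyl in place of hydrogen on the saturated chain carbon, two bonds along the chain from an aromatic carbon, gives a 2.1-fold lower number from compound 1 to compound 3 (0.33 log units; beyond the scatter) in this assay and is the only step of the three that clears the scatter, though only modestly. Methyl in place of 1-hydroxy-1-methylethyl gives a 1.6-fold lower number from compound 2 to compound 3 (0.19 log units; within the scatter) and so does not tell these two compounds apart, which means the plain chain end and the end carrying the hydroxy group cannot be separated at this place. Nothing measured here explains either step.

As far as these compounds go, it remains open whether a longer chain would carry the modest gain further or lose it. Equally open, from the compounds shown here alone, is how an amine or a carboxylic acid at the chain end would compare with the plain chain of compound 3 and the hydroxy-bearing chain of compound 2.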